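The source may report more compounds than this note shows. Statements on the series, on what has been measured and on what is new or still open speak of the compounds shown alone.

Compound 1 `C=Cc1ccc(S(=O)(=O)Nc2ccc3oc(-c4ccccc4)nc3c2)cc1` and compound 2 `CCc1ccc(S(=O)(=O)Nc2ccc3oc(-c4ccccc4)nc3c2)cc1` share one core, and differ only where an ethyl replaces a vinyl on an aromatic carbon. In an assay on cells for inhibition of HSP60/HSP10 (Homo sapiens), with a stated time of 60 min (on this read-out lower numbers stand for stronger inhibition and higher numbers for weaker inhibition), compound 1 gives > 100000 nM, a limit of the assay rather than a number. In this assay compound 2 gives > 100000 nM, again only a limit. The step that the two limits leave unreadable from compound 1 to compound 2 therefore cannot be read, and the only firm point is the limit of > 100000 nM in this assay, at which 2 of the 2 values shown sit, so compound 2 stands at the limit with no numbered value of its own.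

Compound 3 `Cc1cccc(S(=O)(=O)Nc2ccc3oc(-c4ccccc4)nc3c2)c1` is not yet measured. It arises from compound 2 by 3-methylphenyl in place of 4-ethylphenyl on a sulfonyl sulfur, in other words a 3-methylphenyl in place of a 4-ethylphenyl on a sulfonyl sulfur. Within the data shown here, only the step from compound 1 to compound 2 could bear on this, and its size is unreadable, so no direction in this assay can be stated and no basis exists for expecting a result that differs from the limit.

The estimate for compound 3 is 150000 nM, with a range from 30000 nM to 1000000 nM, which is an expected step that the limit leaves unreadable from compound 2 to compound 3; most likely the assay again reports only a limit.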

Compound 3, half-maximal inhibitory concentration: > 100000 nM
Compound 3: only a limit was reported; the forecaster's own chance of this, stated with the estimate: 85%; the middle value is on the limit's open side.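

In this assay compound 3 gives > 100000 nM as a limit of the assay, not a number. With compound 1 and compound 2 also reported only as limits, no step among these three compounds can be read. The compounds shown leave open how strongly each one inhibits, and whether changing the group on the sulfonyl sulfur makes any difference.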